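One Added Methyl and an Expected Potency

The compounds below may be only part of what the source reports. "The series", "measured", "known", "first", "only" and "open" are said of these compounds alone.

Measured so far in an assay on isolated protein for inhibition of Indoleamine 2,3-dioxygenase 1 (Homo sapiens), read by HPLC, with a stated time of 60 min, in the presence of a further agent that is not named here; a lower number here means a stronger inhibitor, a higher number a weaker inhibitor:
Compound 1 `Clc1ccc2[nH]cc(Sc3ccccc3)c2c1` gives > 200000 nM.
Compound 2 `Cc1ccc(Sc2c[nH]c3ccc(Cl)cc23)cc1` gives > 200000 nM.
Compound 3 `COc1cc(OC)cc(Sc2c[nH]c3ccc(Cl)cc23)c1` gives 7000 nM.

The value of compound 1 is a limit of the assay, not a number. The value of compound 2 is likewise a limit. Both sit at the limit of > 200000 nM in this assay, at which 2 of the 3 values shown sit, so the step that the two limits leave unreadable from compound 1 to compound 2, made by methyl in place of hydrogen on an aromatic carbon, has no readable size. For the measured compounds named here, compound 3 gives the only real number in this assay .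

Compound 4 `COc1cc(OC)cc(Sc2c(C)[nH]c3ccc(Cl)cc23)c1` is not yet measured. It differs from compound 3 by methyl in place of hydrogen on an aromatic carbon. This is the same kind of change as that from compound 1 to compound 2, but the place differs: in compound 2 the methyl sits on a six-membered aromatic ring of carbon only, para to a large group, whereas in compound 4 it sits on a five-membered aromatic ring with 1 nitrogen, next to the ring nitrogen. The difference between the cores of compound 1 and compound 3 is not broken down here.

Because the earlier step that the two limits leave unreadable from compound 1 to compound 2 is unreadable, the expected step of a 1.4-fold higher number from compound 3 to compound 4 (0.15 log units; within the scatter) rests only on compound 3 and its value 7000 nM, with a small methyl expected to move potency little. Compound 4 is therefore estimated at about 10000 nM, expected between 2000 nM and 50000 nM.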

Compound 4, half-maximal inhibitory concentration: 45000 nM
Compound 4: middle estimate off by 4.5-fold (0.65 log units), on the low side, and the stated range covers the measured number.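

In this assay, methyl in place of hydrogen on an aromatic carbon gives a 6.4-fold higher number from compound 3 to compound 4 (0.81 log units; beyond the scatter), so at this place on this core the added methyl weakens inhibition by more than the usual scatter. The same kind of change from compound 1 to compound 2 cannot be read, because both compounds sit at a limit of the assay: the limit of > 200000 nM in this assay, at which 2 of the 4 values shown sit. The series therefore offers one readable step, with the methyl in a different place in each pair, and it does not show whether the effect carries from one core to another.

The compounds shown leave open how a longer chain, an amine or a carboxylic acid on that same carbon would read. They also leave open what methyl on that carbon would do with the other aryl groups shown.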